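Sulfonyl-piperidine series: ring size at the basic amine

The compounds below may be only part of what the source reports. "The series", "measured", "known", "first", "only" and "open" are said of these compounds alone.

Measured compounds:
compound 1, `CC(=O)Nc1ccc(S(=O)(=O)N2CCC(N3CCC(C)CC3)CC2)c2ccccc12`, 1100 nM
compound 2, `Cc1cc(C)c(S(=O)(=O)N2CCC(N3CCCCCC3)CC2)c(C)c1`, 5.3 nM
compound 3, `CC1CCN(C2CCN(S(=O)(=O)c3cccc(Br)c3)CC2)CC1`, 3.2 nM

In a functional assay on DLD-1 cells (Homo sapiens) for antiproliferative activity, read by CellTiter-Glo, with a stated time of 72 h (on this read-out lower numbers stand for stronger inhibition and higher numbers for weaker inhibition), compound 2 stands second highest of the three numbers. Its nearest neighbour is compound 3, whose value of 3.2 nM lies within the scatter of compound 2, so no order between the two can be read. The furthest is compound 1, whose value of 1100 nM lies well beyond the scatter, and that gap goes with changes in both the aryl part and the amine, so it tells nothing on its own about the amine ring.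

Compound 4, `Cc1cc(C)c(S(=O)(=O)N2CCC(N3CCCCC3)CC2)c(C)c1`, has not been measured. It differs from compound 2 as follows: piperidin-1-yl in place of azepan-1-yl on a saturated ring carbon. Going by the values given here, the only other pair that touches the same saturated ring carbon, compound 1 against compound 3, changes the aryl group at the same time and so gives no clean reading for the amine ring alone.

With no measured step of this kind in the series, the expectation is that the change from azepan-1-yl to piperidin-1-yl produces no step beyond the scatter in this assay, in either direction. The step of a 1.3-fold higher number from compound 2 to compound 4 (0.12 log units; within the scatter) is accordingly the estimated outcome. For compound 4 the estimated value is 7 nM, with a range from 2.5 nM to 22 nM.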

Compound 4, half-maximal inhibitory concentration: 2200 nM
Beside the measured number, compound 4's estimate is 310-fold (2.50 log units) below it, and the stated range ends below it.
By their numbers in this assay, from the lowest: compounds 3 and 2 (each within the scatter of the next); then compounds 1 and 4 (each within the scatter of the next).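

In this assay, the saturated ring carbon bearing the amine gives its first clean reading, with a 420-fold higher number from compound 2 to compound 4 (2.62 log units; beyond the scatter) while the rest of the molecule stays the same. This position is therefore far from tolerant of the change: contracting the seven-membered azepan-1-yl to the six-membered piperidin-1-yl removes one ring carbon and leaves the counted hydrogen-bond donors, the counted acceptors and the net charge the same, yet the step is large. Nothing available bears on what lies behind a step of this size.

The compounds shown leave open how the trend in ring size continues, for instance with the smaller pyrrolidin-1-yl, the larger azocan-1-yl, or an open-chain diethylamino group at the same ring carbon, and whether an added ring oxygen, as in morpholin-4-yl, would be accepted. Going by these compounds alone, it also remains open whether a step of this size holds with other aryl groups on the sulfonyl, since the only clean reading for the amine ring comes from the core shared by compound 2 and compound 4.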